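This account rests on a few compounds, and the source may have more. Where it says the series, first, only, none or still open, it means among the compounds named here.

Values in a functional assay on PC-3 cells (Homo sapiens) for antiproliferative activity, read by MTT assay, with a stated time of 72 h (on this read-out lower numbers stand for stronger inhibition and higher numbers for weaker inhibition), so far

- Compound 1 `CCn1c(C(=O)NCCCO)ccc1C(CC)(CC)c1ccc(C#CC(O)(CC)CC)c(C)c1` gives > 50000 nM as a limit of the assay, not a number
- Compound 2 `CCN(CC)CCNC(=O)c1cc(C(CC)(CC)c2ccc(C#CC(O)(CC)CC)c(C)c2)cn1CC` gives 5350 nM
- Compound 3 `CCCCC(=O)c1cc(C(CC)(CC)c2ccc(C#CC(O)(CC)CC)c(C)c2)cn1CC` gives 48100 nM

Of the two numerical values, compound 3 holds the higher, with compound 2 the nearest and only comparison. The reading for compound 1 is the limit of > 50000 nM in this assay, at which 1 of the 3 values shown sits, and says no more than that.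

Next is compound 4 `CCn1cc(C(CC)(CC)c2ccc(C#CC(O)(CC)CC)c(C)c2)cc1C(=O)N[C@@H](C)CO`, which has (1-(hydroxymethyl)ethyl)amino in place of butyl on a carbonyl carbon, as counted here: (1-(hydroxymethyl)ethyl)amino in place of butyl on a carbonyl carbon.

Going by the values given here, one measured step bears on this change, at the same carbonyl carbon: a 9.0-fold higher number from compound 2 to compound 3 (0.95 log units; beyond the scatter). Read in reverse, that step suggests that an amino group in place of butyl may lower the number in this assay. However, the (2-(diethylamino)ethyl)amino group of compound 2 does not return in compound 4, so only part of that step is expected, and a step within the scatter is quite possible. A limit reading also remains possible for compound 4.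

The expected step is a 1.9-fold lower number from compound 3 to compound 4 (0.28 log units; within the scatter), towards a lower number. For compound 4 the estimated value is 25000 nM, with an expected range from 8000 nM to 60000 nM.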

Compound 4, half-maximal inhibitory concentration: 6050 nM
Compound 4: the middle estimate sits 4.1-fold (0.62 log units) above what was measured, and the stated range ends above it.
By their numbers in this assay, from the lowest: compounds 2 and 4 (each within the scatter of the next); then compound 3. At a limit, above all of these: compound 1.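

In this assay, a second amino group on the carbonyl carbon now lowers the number relative to butyl, with a clear step (an 8.0-fold lower number from compound 3 to compound 4 (0.90 log units; beyond the scatter)). The (1-(hydroxymethyl)ethyl)amino group has no diethylamino end, and the change between the two amino groups stays within the scatter (a 1.1-fold higher number from compound 2 to compound 4 (0.05 log units; within the scatter)), so across compounds 2, 3 and 4 the drop from butyl does not depend on that end. No measurement shown gives a cause for either step.

Compound 1, which also carries an amino group on a carbonyl carbon, gives (> 50000 nM), a limit of the assay and not a number, and it differs from the other compounds in more than one place, so it can neither support nor contradict this reading. The compounds shown leave open whether a plain primary amide, a short alkylamino group such as methylamino, a carboxylic acid or the opposite configuration at the defined stereocentre of (1-(hydroxymethyl)ethyl)amino would hold the number at this level, and whether any group on this carbonyl carbon can take it clearly lower than compounds 2 and 4.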